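The source may hold more compounds than are shown below. What is called first, only, known or untested is meant among the compounds shown, and "the series" means these compounds.

Measured compounds in a functional assay on JAR cells (Homo sapiens) for inhibition, read by MTT assay, with a stated time of 72 h; on this read-out lower numbers stand for stronger inhibition and higher numbers for weaker inhibition:
Compound 1 `CCOC(=O)C1=C(Nc2ccccc2)S/C(=C\c2ccc(O)c(O)c2)C1=O` gives 6100 nM.
Compound 2 `CCOC(=O)C1=C(Nc2ccc(F)cc2)S/C(=C\c2ccc[nH]2)C1=O` gives 15900 nM.
Compound 3 `CCOC(=O)C1=C(Nc2ccc([N+](=O)[O-])cc2)S/C(=C\c2ccc[nH]2)C1=O` gives 15600 nM.

Compound 1 stands lowest of the three numbers in this assay; compound 2 and compound 3 both lie above it by more than the scatter, and the two of them sit within the scatter of each other. Within the data shown here, the only step between compounds differing in one place is a 1.0-fold lower number from compound 2 to compound 3 (0.01 log units; within the scatter), which concerns the anilino ring, not the arylidene position.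

Compound 4 `CCOC(=O)C1=C(Nc2ccccc2)S/C(=C\c2cc3cccnc3[nH]2)C1=O` differs from compound 1 by a group of 9 heavy atoms (7 carbon, 2 nitrogen; one five-membered aromatic ring with 1 hetero atom, one six-membered aromatic ring with 1 hetero atom) in place of a group of 8 heavy atoms (6 carbon, 2 oxygen; one six-membered aromatic ring of carbon only), on a double-bonded chain carbon bound to a double-bonded ring carbon. Among the measured compounds shown here, no measured step bears directly on this change: compound 2 and compound 3 carry a different five-membered group at that position but also a different anilino substituent, so their gap to compound 1 cannot be split into parts. For the measured compounds named here, the only guide is that both of them give higher numbers than compound 1. Compound 4 is therefore expected to give a somewhat higher number, with wide uncertainty, a 1.5-fold higher number from compound 1 to compound 4 (0.17 log units; within the scatter). The estimate for compound 4 in this assay is 9000 nM, within a range from 3000 nM to 27000 nM.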

Compound 4, half-maximal inhibitory concentration: 14400 nM
Compound 4: middle estimate off by 1.6-fold (0.20 log units), on the low side; the measured number falls inside the stated range.
By their numbers in this assay, from the lowest: compound 1; then compounds 4, 3 and 2 (each within the scatter of the next).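

The position can now be read on its own, with the anilino ring unsubstituted on both sides of the comparison. In this assay, the group with a five-membered and a six-membered aromatic ring, in place of 3,4-dihydroxyphenyl on the double-bonded chain carbon bound to a double-bonded ring carbon, gives a 2.4-fold higher number from compound 1 to compound 4 (0.37 log units; beyond the scatter), so this position responds to the change, though only modestly. Nothing available accounts for this shift.

As far as these compounds go, what a plain phenyl or a phenyl with a single hydroxyl group would give at this position remains open, so the shift cannot be assigned to the hydroxyl groups or to the rings themselves. Also open, from the compounds shown here alone, is whether a methoxy group on the anilino ring would leave the size of this step unchanged.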